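A few compounds are considered here, and "the series" means these few. Any claim that something is new, unique, unknown or untested is made for them only; others in the source may bear on it.

Measured compounds:
Compound 1 `COc1cc(-c2nnc(SCc3ccc(F)cc3)n2/N=C/c2ccccc2)cc(OC)c1OC` gives > 200000 nM in a functional assay on MKN-45 cells (Homo sapiens) for cytotoxicity, read by MTT assay, with a stated time of 48 h; on this read-out higher numbers stand for weaker inhibition and lower numbers for stronger inhibition.
Compound 2 `COc1ccc(/C=N/n2c(SC)nnc2-c2cc(OC)c(OC)c(OC)c2)c(OC)c1` gives > 200000 nM in this assay.

Both values are limits of the assay and not numbers. Compound 2 therefore stands at the limit of this assay, with no number of its own, and the value of compound 1 sits at the same limit (the limit of > 200000 nM in this assay, at which 2 of the 2 values shown sit). Among the compounds with values here, no step between two measured compounds is available here, so the size of any change must be guessed from the structures alone.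

Compound 3 `COc1ccc(/C=N/n2c(SCc3ccc(F)cc3)nnc2-c2cc(OC)c(OC)c(OC)c2)c(OC)c1` differs from compound 2 by 4-fluorophenyl in place of hydrogen on a saturated chain carbon bound to a sulfur. Compound 1 carries the same (4-fluorobenzyl)sulfanyl group as compound 3, and compound 1 sits at the limit. From compound 2 to compound 3 the expected step of a number no higher from compound 2 to compound 3 (the limit leaves the size open) is none beyond the scatter in this assay. Compound 3 is accordingly expected to remain at the limit, around 200000 nM, with a range from 100000 nM to 400000 nM.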

Compound 3, half-maximal inhibitory concentration: > 200000 nM
Compound 3: only a limit was reported; the forecaster's own chance of this, stated with the estimate: 80%; the middle value lies on the limit itself.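

Compound 3 gives > 200000 nM in this assay, which is a limit and not a number. The steps to compound 3 from compound 1 and from compound 2 therefore cannot be read: the limit of > 200000 nM in this assay, at which 3 of the 3 values shown sit.

The compounds shown leave open whether either change affects cytotoxicity at all.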